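Stereochemical Inversion on the Phenylethyl Side Chain

The source may report more compounds than this note shows. Statements on the series, on what has been measured and on what is new or still open speak of the compounds shown alone.

Compound 2 `Cc1nc(N[C@H](C)c2ccccc2)nc(N[C@@H]2C[C@H](CO)[C@@H](O)[C@H]2O)c1-c1nc2cnccc2s1` gives 98.5 ng.h/mL in an ADME assay on the whole organism (plasma) for pharmacokinetics, with Rattus norvegicus as the target, with a stated time of 6 h, at a dose of 10 mg/kg by the oral route (on this read-out higher numbers stand for higher exposure at the dose given and lower numbers for lower exposure), the lowest of the two numbers shown; the nearest is compound 1 `Cc1nc(NC2CC2)nc(N[C@@H]2C[C@H](CO)[C@@H](O)[C@H]2O)c1-c1nc2cnccc2s1`, which gives 600 ng.h/mL. Among the compounds with values here, the one measured step, a 6.1-fold lower number from compound 1 to compound 2 (0.78 log units; beyond the scatter), concerns a change of group rather than of configuration. Compound 3 `Cc1nc(N[C@@H](C)c2ccccc2)nc(N[C@@H]2C[C@H](CO)[C@@H](O)[C@H]2O)c1-c1nc2cnccc2s1` differs from compound 2 only in that (the two compounds have the same atoms and bonds and differ only in configuration as drawn: 1 of 5 stereo elements differ; a stereocentre at a saturated chain carbon is drawn R in compound 2 and S in compound 3). Within the data shown here, no measured step bears on a change of this kind, so the step is expected to stay within the scatter, in no set direction: a 1.0-fold higher number from compound 2 to compound 3 (0.01 log units; within the scatter). Compound 3 is therefore estimated at 100 ng.h/mL, within 30 ng.h/mL to 330 ng.h/mL.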

Compound 3, area under the concentration-time curve: 49.3 ng.h/mL
Compound 3: the middle estimate sits 2.0-fold (0.31 log units) above what was measured, and the stated range covers the measured number.
By their numbers in this assay, from the lowest: compounds 3 and 2 (each within the scatter of the next); then compound 1.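

In this assay the inversion at the saturated chain carbon gives a 2.0-fold lower number from compound 2 to compound 3 (0.30 log units; within the scatter) and so stays within the scatter, which means the drawn configuration at this centre shows no clear effect on exposure. The S form also stands well apart from the cyclopropyl compound, with a 12-fold lower number from compound 1 to compound 3 (1.09 log units; beyond the scatter) beyond the scatter, so the gap first seen with the R form holds for both configurations. This pair isolates a single change: the fact that compounds 2 and 3 differ only in the configuration as drawn

Still open, on these data alone, is whether a benzyl group or a longer alkyl chain on the same nitrogen would stay near compound 1 or near compound 2. Also open, as far as these compounds go, is whether a fluorine on the phenyl ring would leave the two configurations within the scatter of each other.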